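Swapping Fluoro for Chloro on a Fused Aromatic Ring

A few compounds are considered here, and "the series" means these few. Any claim that something is new, unique, unknown or untested is made for them only; others in the source may bear on it.

Two pairs of compounds share a single structural change. Compound 1 `CC1(C)CC(NC(=S)Nc2ccc(C#N)cc2)c2cc(F)ccc2O1` and compound 2 `CC1(C)CC(NC(=S)Nc2ccc(C#N)cc2)c2cc(Cl)ccc2O1` differ in that compound 2 carries chloro in place of fluoro on an aromatic carbon. In a functional assay on B16-F10 cells (Mus musculus) for inhibition, read by MTT assay, with a stated time of 72 h (on this read-out higher numbers stand for weaker inhibition and lower numbers for stronger inhibition), compound 1 gives 5000 nM, and in this assay compound 2 gives 7000 nM, so the change produced a 1.4-fold higher number from compound 1 to compound 2 (0.15 log units; within the scatter). In plain terms, the two values cannot be told apart by this kind of measurement.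

Compound 3 `CC1(C)CC(NC(=O)Nc2ccc(Cl)cc2)c2cc(F)ccc2O1` has no single number in this assay: in this assay compound 3 is recorded as "not determined" (no result reported). The difference between the core of compound 3 and the core of compound 1 is not broken down here. Compound 4 `CC1(C)CC(NC(=O)Nc2ccc(Cl)cc2)c2cc(Cl)ccc2O1` is compound 3 with chloro in place of fluoro on an aromatic carbon. Within the data shown here, this is the same change as the one from compound 1 to compound 2, in the same place.

Among the measured compounds shown here, for compound 4, the only guide to the size of the step from compound 3 is that the same change produced a 1.4-fold higher number from compound 1 to compound 2 (0.15 log units; within the scatter). Since compound 3 has no number of its own, the level of compound 4 is expected to lie near the values of compound 1 and compound 2, with wide uncertainty. Compound 4 is estimated to give about 6000 nM in this assay, expected to fall between 1500 nM and 25000 nM.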

Compound 4, half-maximal inhibitory concentration: 32000 nM
Compound 4: the middle estimate sits 5.3-fold (0.73 log units) below what was measured, and the stated range ends below it.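

Compound 3 has no number in this assay so the change from fluoro to chloro between compound 3 and compound 4 cannot be read as a step. The compounds shown leave open how much of the level of compound 4 comes from that change and how much from its other differences from compound 2. No supporting evidence bears on this result.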